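The source may hold more compounds than are shown below. What is called first, only, known or untested is meant among the compounds shown, and "the series" means these compounds.

Compound 1 `Oc1ccc(-c2cc(-c3ccoc3)cc(-c3cccc(O)c3)n2)cc1` gives 2700 nM in a functional assay on DU-145 cells (Homo sapiens) for cytotoxicity, read by CCK-8 assay; a higher number here means a weaker inhibitor, a lower number a stronger inhibitor. Compound 2 `Oc1ccc(-c2cc(-c3ccoc3)cc(-c3ccc(O)cc3)n2)cc1` is the same molecule with 4-hydroxyphenyl in place of 3-hydroxyphenyl on an aromatic carbon; in this assay compound 2 gives 3440 nM, so this change made a 1.3-fold higher number from compound 1 to compound 2 (0.11 log units; within the scatter). Compound 3 `Oc1cccc(-c2cc(-c3cccnc3)cc(-c3cccc(O)c3)n2)c1` is built on a different core, and the difference between the two cores is not broken down here. In this assay compound 3 gives > 50000 nM, which is a limit of the assay and not a number; it is the limit (the limit of > 50000 nM in this assay, at which 1 of the 3 values shown sits). Compound 4 `Oc1ccc(-c2cc(-c3cccnc3)cc(-c3cccc(O)c3)n2)cc1` is not yet measured and stands to compound 3 as compound 2 stands to compound 1, with 4-hydroxyphenyl in place of 3-hydroxyphenyl on an aromatic carbon. The surroundings differ, though: in compound 1 the exchanged group sits meta to a 4-hydroxyphenyl group and meta to a furan-3-yl group, whereas in compound 3 it sits meta to a 3-hydroxyphenyl group and meta to a pyridin-3-yl group, so the two changes are of the same kind but not the same. The earlier change gave only a 1.3-fold higher number from compound 1 to compound 2 (0.11 log units; within the scatter), and on that the new one is expected to make a step that the limit leaves unreadable from compound 3 to compound 4. Compound 4 is therefore estimated at 60000 nM, between 25000 nM and 150000 nM.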

Compound 4, half-maximal inhibitory concentration: 6390 nM
The estimate for compound 4 lay 9.4-fold (0.97 log units) above the measured number; measured number outside the range, below it.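

The exchange of 3-hydroxyphenyl for 4-hydroxyphenyl did not carry over unchanged between these two cores in this assay, where it gave an at least 7.8-fold lower number from compound 3 to compound 4 (0.89 log units; beyond the scatter), and the comparison with the earlier step shows a clear difference: the same change on two cores in this assay, a 1.3-fold higher number (0.11 log units; within the scatter) from compound 1 to compound 2 and an at least 7.8-fold lower number (0.89 log units; beyond the scatter) from compound 3 to compound 4, at least 9.9-fold (0.99 log units) apart, beyond the scatter of two such steps

For compound 3, the reading of > 50000 nM is a limit of the assay and not a number: the limit of > 50000 nM in this assay, at which 1 of the 4 values shown sits.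

The comparison rests on one pair per core and does not show why the two steps differ, while a separate exchange, pyridin-3-yl in place of furan-3-yl, gave a 2.4-fold higher number from compound 1 to compound 4 (0.37 log units; beyond the scatter).

The compounds shown leave open whether a methoxy group or an amine in place of either hydroxyl would follow the same course. They also leave open how the exchange would behave with a thiophene in place of furan-3-yl or pyridin-3-yl.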